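All Three Spiro Compounds Sit at the Assay Ceiling

This account rests on a few compounds, and the source may have more. Where it says the series, first, only, none or still open, it means among the compounds named here.

Three close relatives of one shared core have been tested in a functional assay on HCT-116 cells (Homo sapiens) for antiproliferative activity, read by MTT assay, with a stated time of 48 h; a higher number here means a weaker inhibitor, a lower number a stronger inhibitor. Compound 1 `CCOc1ccccc1-n1nncc1CN1C(=O)C2(C(C#N)=C(N)Oc3c2c2nc4ccccc4nc2c2ccccc32)c2ccccc21` carries a 2-ethoxyphenyl group on an aromatic nitrogen of its triazole ring. In this assay compound 1 gives > 50000 nM, which is a limit of the assay and not a number. Compound 2 `N#CC1=C(N)Oc2c(c3nc4ccccc4nc3c3ccccc23)C12C(=O)N(Cc1cnnn1-c1ccc(F)c(Cl)c1)c1ccccc12` differs only at that aromatic nitrogen. In this assay compound 2 gives > 50000 nM, again a limit rather than a number. The step that the two limits leave unreadable from compound 1 to compound 2 therefore cannot be read, since both ends are limits. Compound 3 `N#CC1=C(N)Oc2c(N)cc3nc4ccccc4nc3c2C12C(=O)N(Cc1cnnn1-c1ccc(Cl)cc1)c1ccccc12` carries an amino group on the core and a 4-chlorophenyl group on the aromatic nitrogen. In this assay compound 3 gives > 50000 nM, also a limit and not a number. What the measurements show as a whole is the limit of > 50000 nM in this assay, at which 3 of the 3 values shown sit.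

Compound 4 `CCc1cccc(C)c1-n1nncc1CN1C(=O)C2(C(C#N)=C(N)Oc3c(N)cc4nc5ccccc5nc4c32)c2ccccc21` is the next candidate. The change from compound 3 is 2-ethyl-6-methylphenyl in place of 4-chlorophenyl on an aromatic nitrogen. For the measured compounds named here, no measured step speaks to this change, and every measured value is a limit, so no direction can be argued. Compound 4 is expected to stay at the ceiling as well, with an estimated value of 60000 nM (range 25000 nM to 150000 nM). The expected step is a step that the limit leaves unreadable from compound 3 to compound 4.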

Compound 4, half-maximal inhibitory concentration: > 50000 nM
Compound 4 was reported as a limit (the forecaster's own chance of this, stated with the estimate: 80%); the middle value is on the limit's open side.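

For the compounds shown here, compound 3 and compound 4 are both reported as limits rather than numbers, so swapping 4-chlorophenyl for 2-ethyl-6-methylphenyl gives no step that can be read, and the whole set looks the same: the limit of > 50000 nM in this assay, at which 4 of the 4 values shown sit. These compounds leave open which change to the shared core or the aromatic-nitrogen group, if any, would give a measurable value.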